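The compounds below may be only part of what the source reports. "The series", "measured", "known", "first", "only" and "open" are said of these compounds alone.

Three compounds that share one core but carry different aromatic rings have been tested in a functional assay on the whole organism for inhibition, with Rattus norvegicus as the target, with a stated time of 1 h; on this read-out higher numbers stand for an effect only at larger amounts of compound and lower numbers for an effect already at smaller amounts. Compound 1 `CC1(C)OC(/C=C/c2ccsc2)=CC1=O` gives 4 mg/kg, compound 3 `CC1(C)OC(/C=C/c2ccncc2)=CC1=O` gives 4 mg/kg, and compound 2 `CC1(C)OC(/C=C/c2ccccc2)=CC1=O` gives 17 mg/kg. Compound 2 therefore has the highest number of the three, meaning that it needs the largest dose for the effect. Compound 4 `CC1(C)OC(/C=C/c2ccc(F)cc2)=CC1=O` alters compound 2 in one place: fluoro in place of hydrogen on an aromatic carbon, with fluoro in place of hydrogen on an aromatic carbon, para to a large group. Going by the values given here, no tested pair differs by a single change like this one, so the data give no direct measure of its size. Compound 1 and compound 3 do show that lower numbers occur in this small set, so a modest move in that direction seems more likely than a rise. The expected change is small, a 1.7-fold lower number from compound 2 to compound 4 (0.23 log units; within the scatter), and may not stand out from the usual scatter. For compound 4 the estimated dose is 10 mg/kg, with an expected range from 3 mg/kg to 30 mg/kg.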

Compound 4, dose for half-maximal effect: 11 mg/kg
Compound 4: middle estimate off by 1.1-fold (0.04 log units), on the low side, and the stated range covers the measured number.
By their numbers in this assay, from the lowest: compounds 1 and 3 (each within the scatter of the next); then compounds 4 and 2 (each within the scatter of the next).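

In this assay, fluoro in place of hydrogen on an aromatic carbon, para to a large group, gives a 1.5-fold lower number from compound 2 to compound 4 (0.19 log units; within the scatter). Going by these compounds alone, this is the only step in the set that changes a single place, so it puts a direct size on one change, and at this position on the six-membered aromatic ring of carbon only, that size cannot be told apart from the differences seen between repeated measurements. No measured information explains this outcome.

On these data alone, one small atom in one place says little about the position as a whole, so it stays open whether a larger group there, such as methoxy or trifluoromethyl, or an amine, would shift the dose beyond the scatter. Also open, as far as these compounds go, is whether fluoro at another place on this ring would behave the same way.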